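The source may report more compounds than this note shows. Statements on the series, on what has been measured and on what is new or still open speak of the compounds shown alone.

Working notes on the series. In an assay on HEK293 cells for positive allosteric modulation of metabotropic glutamate receptor 5 (Homo sapiens), read by FLIPR, with a stated time of 1 h (a higher number here means that more compound is needed for the effect, a lower number that less compound is needed), compound 1 `CN1CCc2nc(C#Cc3cccc(F)c3)sc2C1` reaches only the limit of the assay, > 10000 nM. Compound 2 `Fc1cccc(C#Cc2nc3c(s2)CN(C2CCC2)CC3)c1` likewise gives only a limit, > 10000 nM. Between them stands a step that the two limits leave unreadable from compound 1 to compound 2, which therefore carries no readable size. Compound 3 `O=C(C1CC1)N1CCc2nc(C#Cc3ccccc3)sc2C1` also gives only a limit, > 10000 nM. Compound 3 thus sits at the limit of > 10000 nM in this assay, at which 3 of the 3 values shown sit, with nothing measured below that limit anywhere in the set. Compound 4 `N#Cc1cccc(C(=O)N2CCc3nc(C#Cc4ccccc4)sc3C2)c1` differs from compound 3 by 3-cyanophenyl in place of cyclopropyl on a carbonyl carbon. Within the data shown here, no measured step touches the amide carbonyl substituent, and the only measured step is unreadable, so no direction can be drawn from the data. Compound 4 is expected near 6000 nM, within 1500 nM to 20000 nM. The expected step from the limit of compound 3 is an at least 1.6-fold lower number from compound 3 to compound 4 (0.22 log units; that floor lies within the scatter), an estimate only.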

Compound 4, half-maximal effective concentration: 71 nM
For compound 4 the middle estimate is 85-fold (1.93 log units) above the measured one, outside the stated range (below it).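

In this assay, among these compounds, the group on the carbonyl carbon is the first place where a change gives a readable gain: 3-cyanophenyl in place of cyclopropyl gives an at least 140-fold lower number from compound 3 to compound 4 (2.14 log units; beyond the scatter). That size is only a floor, as compound 3 carries a limit and not a number. Compound 4 is the only compound shown that gets past this limit: the limit of > 10000 nM in this assay, at which 3 of the 4 values shown sit.

The change brings in the aromatic ring and the nitrile together, and the compounds shown do not separate the two. A plain phenyl on the same carbonyl carbon would show how much of the step remains without the nitrile.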